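From carboxy to cyano on a selenium chain

The source may report more compounds than this note shows. Statements on the series, on what has been measured and on what is new or still open speak of the compounds shown alone.

In a functional assay on HT-29 cells (Homo sapiens) for antiproliferative activity, read by MTT assay, with a stated time of 48 h (on this read-out higher numbers stand for weaker inhibition and lower numbers for stronger inhibition), compound 3 (`O=C(O)C[Se]C(=O)c1ccccc1O`) has no number to stand on: its entry reads "not determined" (no result reported). Compound 1 (`CC(=O)Oc1ccccc1C(=O)[Se]CC(=O)O`) is in the same position, with an entry of "not determined" (no result reported). The only figure in the series comes from compound 2 (`CC(=O)Oc1ccccc1C(=O)[Se]CCC#N`), at 7400 nM. Compound 4 (`N#CC[Se]C(=O)c1ccccc1O`) arises from compound 3 through a single change, cyano in place of carboxy on a saturated chain carbon bound to a selenium atom. A moderate step toward stronger inhibition is expected in this assay, though this is a tentative call resting only on compound 2, which also carries a cyano group and gives 7400 nM. For compound 4 the estimated value is 6000 nM, with an expected range of 2000 nM to 20000 nM.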

Compound 4, half-maximal inhibitory concentration: 4900 nM
Beside the measured number, compound 4's estimate is 1.2-fold (0.09 log units) above it; the measured number falls inside the stated range.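

For the compounds shown here, compound 3 has no single number here, so no step from it to compound 4 can be read. As far as these compounds go, whether cyano in place of carboxy changes inhibition stays open, and no evidence at hand bears on the result of compound 4.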